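A Benzyl Change Beside Three Limits in Cytotoxicity

A few compounds are considered here, and "the series" means these few. Any claim that something is new, unique, unknown or untested is made for them only; others in the source may bear on it.

Compound 1 `O=c1ccoc2cc(OCc3cn(Cc4cccc(Br)c4)nn3)ccc12` carries a 3-bromophenyl on a saturated chain carbon bound to an aromatic nitrogen. In a functional assay on SGC-7901 cells (Homo sapiens) for cytotoxicity, read by MTT assay, with a stated time of 48 h (a lower number here means a stronger inhibitor, a higher number a weaker inhibitor), compound 1 gives > 100000 nM, which is a limit of the assay and not a number. Compound 2 `O=c1ccoc2cc(OCc3cn(Cc4ccc(Cl)cc4Cl)nn3)ccc12` gives > 100000 nM in this assay, again a limit. Compound 3 `O=c1ccoc2cc(OCc3cn(Cc4cccc([N+](=O)[O-])c4)nn3)ccc12` gives > 100000 nM in this assay, a limit as well. None of the steps among these three can be sized: a step that the two limits leave unreadable from compound 1 to compound 2, a step that the two limits leave unreadable from compound 1 to compound 3 and a step that the two limits leave unreadable from compound 2 to compound 3 are each left unreadable by the two limits they join. The whole measured set therefore sits on a single mark, (the limit of > 100000 nM in this assay, at which 3 of the 3 values shown sit).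

Compound 4 `O=c1ccoc2cc(OCc3cn(Cc4ccccc4Cl)nn3)ccc12` has not yet been measured in this assay. It differs from compound 1 by 2-chlorophenyl in place of 3-bromophenyl on a saturated chain carbon bound to an aromatic nitrogen. No measured step bears on this change in a readable way, since every step shown joins two limits, and the three measured benzyl variations gave no readable difference among them. Compound 4 is therefore expected to sit at the same limit, with an expected step that the limit leaves unreadable from compound 1 to compound 4 in this assay. The estimate for compound 4 is 150000 nM, within a range of 60000 nM to 400000 nM, most probably reported again only as a limit.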

Compound 4, half-maximal inhibitory concentration: > 100000 nM
Compound 4 gave a limit, no number; the forecaster's own chance of this, stated with the estimate: 85%; the middle value lies beyond the limit too.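

In this assay compound 4 gives > 100000 nM, a limit of the assay and not a number. No step from compound 4 to compound 1, compound 2 or compound 3 can be read, and all four compounds stand on one mark: the limit of > 100000 nM in this assay, at which 4 of the 4 values shown sit.

The compounds shown leave open whether these benzyl groups differ at all in this assay, since none of the four has given a number.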